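Cyclohexyl to 4-methoxyphenyl on the chain of compound 3

The source may hold more compounds than are shown below. What is called first, only, known or untested is meant among the compounds shown, and "the series" means these compounds.

Compound 3 `COC1=C(CCC2CCCCC2)C(=O)c2c(OC)cc(OC)cc2C1=O` gives the lowest number among the measured values in a functional assay on NCI-H460 cells (Homo sapiens) for antiproliferative activity, read by MTT assay (on this read-out lower numbers stand for stronger inhibition and higher numbers for weaker inhibition), at 43100 nM. Its nearest neighbour is compound 2 `COc1ccc(CCC2=C(O)C(=O)c3cc(OC)cc(OC)c3C2=O)cc1`, which in this assay gives 97500 nM. Compound 1 `COc1ccc(CCC2=C(Cl)C(=O)c3cc(OC)cc(OC)c3C2=O)cc1` reaches only a limit in this assay, > 100000 nM, which is a limit of the assay rather than a number (the limit of > 100000 nM in this assay, at which 1 of the 3 values shown sits). Among the measured compounds shown here, the one measured single step is an at least 1.0-fold lower number from compound 1 to compound 2 (0.01 log units; that floor lies within the scatter), a change on a double-bonded ring carbon, unrelated to the chain end.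

Compound 4 `COC1=C(CCc2ccc(OC)cc2)C(=O)c2c(OC)cc(OC)cc2C1=O` differs from compound 3 by 4-methoxyphenyl in place of cyclohexyl on a saturated chain carbon, two bonds along the chain from a double-bonded ring carbon. For the measured compounds named here, no measured step covers this exchange, and compound 2 differs from compound 4 in more than one place, so its value is only a loose reference point. Given the lack of a bearing step, no shift beyond the scatter is assumed, and compound 4 is expected to land at about 45000 nM in this assay, a step of a 1.0-fold higher number from compound 3 to compound 4 (0.02 log units; within the scatter), with the estimate spanning 15000 nM to 130000 nM.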

Compound 4, half-maximal inhibitory concentration: 37100 nM
Compound 4: middle estimate off by 1.2-fold (0.08 log units), on the high side; measured number inside the range.
By their numbers in this assay, from the lowest: compounds 4 and 3 (each within the scatter of the next); then compound 2. At a limit, above all of these: compound 1.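

In this assay, the chain end tolerates the exchange of a saturated ring for an aromatic one: a 1.2-fold lower number from compound 3 to compound 4 (0.07 log units; within the scatter), so 4-methoxyphenyl and cyclohexyl cannot be told apart at this position. With the 4-methoxyphenyl chain end held fixed, the group on the double-bonded ring carbon does register, with methyl in place of hydrogen on the oxygen giving a 2.6-fold lower number from compound 2 to compound 4 (0.42 log units; beyond the scatter) and methoxy in place of chloro giving an at least 2.6-fold lower number from compound 1 to compound 4 (0.43 log units; beyond the scatter). Compound 1 stands at a limit of the assay, not a number, and the second of these steps is only a floor: the limit of > 100000 nM in this assay, at which 1 of the 4 values shown sits.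

On these data alone, it remains open whether the step from hydroxy to methoxy carries over to the cyclohexyl chain end. Also open, as far as these compounds go, is whether an unsubstituted phenyl, a longer chain or an amine at the chain end would move the number beyond the scatter.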